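Working notes: from compound 1 to compound 3

This account rests on a few compounds, and the source may have more. Where it says the series, first, only, none or still open, it means among the compounds named here.

Compound 1 `COc1ccc(Cn2nnc(O)c2C(=O)Nc2cccc(C(F)(F)F)c2)cc1` gives 81400 nM in a functional assay on CWR22R cells (Homo sapiens) for inhibition, read by sulforhodamine B assay, with a stated time of 72 h; on this read-out lower numbers stand for stronger inhibition and higher numbers for weaker inhibition
Compound 2 `COc1ccc(Cn2nnc(O)c2C(=O)Nc2cc(C(F)(F)F)cc(C(F)(F)F)c2)cc1` gives 33800 nM in this assay

Among the compounds with values here, of the two numbers so far, compound 1 holds the higher, and compound 2 is its only neighbour. Compound 3 `COc1ccc(Cn2nnc(O)c2C(=O)Nc2cccc(-c3ccccc3)c2)cc1` has not yet been measured in this assay and differs from compound 1 as follows: phenyl in place of trifluoromethyl on an aromatic carbon.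

Within the data shown here, only one measured step bears on this change, and only indirectly. It is a 2.4-fold lower number from compound 1 to compound 2 (0.38 log units; beyond the scatter), with trifluoromethyl in place of hydrogen on an aromatic carbon, and it is modest though beyond the scatter. That step adds a group where compound 3 swaps one, so it gives a rough size and no more. Among the measured compounds shown here, no measured compound carries phenyl at this place. For the measured compounds named here, a small move toward a lower number is therefore expected, no larger than the step to compound 2, and possibly none beyond the scatter. The expected change is a 1.6-fold lower number from compound 1 to compound 3 (0.21 log units; within the scatter) in this assay, an estimate with wide margins. For compound 3 the estimated value is 50000 nM, with an expected range from 18000 nM to 120000 nM on this single step.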

Compound 3, half-maximal inhibitory concentration: 52100 nM
Beside the measured number, compound 3's estimate is 1.0-fold (0.02 log units) below it; measured number inside the range.
By their numbers in this assay, from the lowest: compounds 2, 3 and 1 (each within the scatter of the next, the first and the last beyond it).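

In this assay, the step (a 1.6-fold lower number from compound 1 to compound 3 (0.19 log units; within the scatter)) is the only one shown that exchanges one group for another at this place on the aromatic ring, meta to a large group; the earlier step only added a trifluoromethyl. It shows that phenyl, with 6 heavy atoms and one six-membered aromatic ring of carbon only, can stand where trifluoromethyl, with 4 heavy atoms and no ring, stands in compound 1, and the two compounds cannot be told apart on this read-out. This single pair therefore gives no sign that the read-out here depends on keeping trifluoromethyl, and no measurement at hand offers an explanation for the two groups reading alike.

The compounds shown hold only trifluoromethyl and phenyl at this place, so the reading of an amine, a carboxylic acid or a longer chain there remains open. Also open is whether phenyl combined with a second trifluoromethyl on the same ring would follow the step (a 2.4-fold lower number from compound 1 to compound 2 (0.38 log units; beyond the scatter)), as no compound shown carries both groups.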